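This account rests on a few compounds, and the source may have more. Where it says the series, first, only, none or still open, it means among the compounds named here.

Within the data shown here, in an ADME assay on HEp-2 cells (Homo sapiens) for cytotoxicity, read by CCK-8 assay, with a stated time of 6 days (on this read-out lower numbers stand for higher toxicity in this test and higher numbers for lower toxicity in this test), compound 3 `NCCNc1cc(N2CCN(S(=O)(=O)c3ccccc3)CC2)nc2ccccc12` gives 20500 nM, the only actual number among the three values shown for this series. Compound 1 `CCC(=O)N1CCN(c2cc(NCCN)c3ccccc3n2)CC1` reaches only a limit of the test, > 100000 nM. Compound 2 `NCCNc1cc(N2CCN(C(=O)C3(c4ccccc4)CC3)CC2)nc2ccccc12` likewise stops at a limit, > 100000 nM. Two of the three values therefore share (the limit of > 100000 nM in this assay, at which 2 of the 3 values shown sit). The step from compound 1 to compound 3, phenylsulfonyl in place of propanoyl on an amine nitrogen in a ring, is an at least 4.8-fold lower number from compound 1 to compound 3 (0.68 log units; beyond the scatter). The step that the two limits leave unreadable from compound 1 to compound 2, 1-phenylcyclopropyl in place of ethyl on a carbonyl carbon, cannot be read because both ends sit at a limit.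

Compound 4 `NCCNc1cc(N2CCN(c3ccccc3)CC2)nc2ccccc12` has not been measured. It differs from compound 3 by phenyl in place of phenylsulfonyl on an amine nitrogen in a ring. Among the measured compounds shown here, only the step from compound 1 to compound 3 touches the same ring nitrogen, and it exchanged a carbonyl group for a sulfonyl group rather than removing the sulfonyl, so it gives no firm guide to direction here. The expected step is a 1.5-fold higher number from compound 3 to compound 4 (0.17 log units; within the scatter), within the scatter. Compound 4 is estimated at 30000 nM, between 8000 nM and 150000 nM.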

Compound 4, half-maximal cytotoxic concentration: 20800 nM
Beside the measured number, compound 4's estimate is 1.4-fold (0.16 log units) above it, and the stated range covers the measured number.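

On the ring nitrogen, the sulfonyl link makes no readable difference in this assay: phenyl in place of phenylsulfonyl gives a 1.0-fold higher number from compound 3 to compound 4 (0.01 log units; within the scatter). Phenyl in place of propanoyl gives an at least 4.8-fold lower number from compound 1 to compound 4 (0.68 log units; beyond the scatter), so the lower number seen earlier with phenylsulfonyl also appears with phenyl on that nitrogen and does not require a sulfonyl group. Compound 2 goes against any simple link to a phenyl ring, since it also carries one yet stops at a limit of the test, > 100000 nM.

On these data alone, the full size of the step from propanoyl stays open, as compound 1 stands at a limit of the test: the limit of > 100000 nM in this assay, at which 2 of the 4 values shown sit. Also open, as far as these compounds go, is whether a benzyl group, a methyl group or a carboxylic acid on the same ring nitrogen would fall with compound 3 and compound 4 or at that limit.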